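Adding a methoxy group to pyrazolyl chalcones against breast cancer cells

The source may report more compounds than this note shows. Statements on the series, on what has been measured and on what is new or still open speak of the compounds shown alone.

Measured compounds:
compound 1 `COc1ccc(-c2cc(/C=C/C(=O)c3ccc(N)cc3)[nH]n2)cc1` gives -65%
compound 2 `COc1ccc(C(=O)/C=C/c2cc(-c3cc(OC)c(OC)c(OC)c3)n[nH]2)cc1OC` gives -84%
compound 3 `COc1ccc(-c2cc(/C=C/C(=O)c3ccc(N)cc3)[nH]n2)cc1OC` gives -77%

All three were tested in a functional assay on MDA-MB-231 cells (Homo sapiens) for cytotoxicity, read by sulforhodamine B assay, with a stated time of 48 h, tested at 100 uM; on this read-out lower numbers stand for a stronger effect and higher numbers for a weaker effect at the one concentration tested. Compound 1 and compound 3 share a core and differ by methoxy in place of hydrogen on an aromatic carbon. That change gave a number 12 percentage points lower from compound 1 to compound 3 (beyond the scatter). The core of compound 2 is different from that of compound 1; the difference between the two cores is not broken down here. Compound 2 gives a number that is within the scatter of compound 3 and beyond the scatter from compound 1.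

Compound 4 `COc1cc(C(=O)/C=C/c2cc(-c3cc(OC)c(OC)c(OC)c3)n[nH]2)cc(OC)c1OC` has not yet been measured. It differs from compound 2 by methoxy in place of hydrogen on an aromatic carbon. Among the compounds with values here, this is the same kind of change as the one from compound 1 to compound 3, but the surroundings are not identical: in compound 4 the new group is also meta to a methoxy group. In this assay, a step of about a number 6 percentage points lower from compound 2 to compound 4 (within the scatter) is expected for compound 4, resting on the step from compound 1 to compound 3 a number 12 percentage points lower from compound 1 to compound 3 (beyond the scatter) and on the already low number of compound 2 -84%. The estimate for compound 4 is therefore -90%, between -100% and -76%.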

Compound 4, a percentage reported as activity, at one concentration (the size of the read-out at that concentration, not a potency): -96%
Compound 4: the middle estimate sits 6 percentage points above what was measured, and the stated range covers the measured number.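

In this assay, placing a methoxy group on the aromatic ring of compound 2 gave a number 12 percentage points lower from compound 2 to compound 4 (beyond the scatter). The same swap of hydrogen for methoxy has now been seen on two different cores, and the size of the step carried over from one to the other: the same change on two cores in this assay, a number 12 percentage points lower (beyond the scatter) from compound 1 to compound 3 and a number 12 percentage points lower (beyond the scatter) from compound 2 to compound 4, 0 percentage points apart, within the scatter of two such steps. This is only a pair of examples at a single concentration, so it shows neither that the step would hold on a third core nor how potency changes, and it does not explain why the two steps match.

The compounds shown carry only hydrogen or methoxy at the changed place, so it remains open whether a hydroxyl group, a fluorine atom or a longer chain such as ethoxy would give a step of similar size. On these data alone, it also remains open whether a methoxy group placed elsewhere on these rings would behave in the same way.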